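Plasma Stability: From Isopropyl Ester to a Carbonate-Bearing Ester

The source may report more compounds than this note shows. Statements on the series, on what has been measured and on what is new or still open speak of the compounds shown alone.

The account follows the step from compound 2 `CC(C)OC(=O)C1=C(S[C@@H]2CN[C@H](C(=O)Nc3cccc(C(=O)O)c3)C2)[C@H](C)[C@@H]2[C@@H]([C@@H](C)O)C(=O)N12` to compound 3 `CCOC(=O)OCOC(=O)C1=C(S[C@@H]2CN[C@H](C(=O)Nc3cccc(C(=O)O)c3)C2)[C@H](C)[C@@H]2[C@@H]([C@@H](C)O)C(=O)N12`. In an ADME assay on a cell-free system (plasma, Homo sapiens) for metabolic stability, read by LC-MS, with a stated time of 60 min, at 37 degrees C, tested at 50 uM (a lower number here means that less of the compound is left, a higher number that more of the compound is left), compound 2 gives "not determined" (no result reported): no result was reported, so it stands nowhere on this scale. The only figure available comes from compound 1 `C[C@@H](O)[C@H]1C(=O)N2C(C(=O)OCOC(=O)C3CCCCC3)=C(S[C@@H]3CN[C@H](C(=O)Nc4cccc(C(=O)O)c4)C3)[C@H](C)[C@H]12`, which in this assay gives 20%. The change from compound 2 to compound 3 is ((ethoxycarbonyl)oxy)methyl in place of isopropyl on an oxygen next to a carbonyl group. For the measured compounds named here, with no number for compound 2, no step in this assay can be set between compound 2 and compound 3, and neither its size nor its direction can be named beyond the scatter or within it. What can be expected for compound 3 rests on compound 1, whose value 20% shows how much of a related compound was left after the stated time. Compound 3 is therefore estimated at 25%, within a range of 5% to 60%.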

Compound 3, percent of the compound remaining in the plasma assay: 10%
Beside the measured number, compound 3's estimate is 15 percentage points above it, and the stated range covers the measured number.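

In the plasma assay, ethoxy in place of cyclohexyl on a carbonyl carbon gives a number 10 percentage points lower from compound 1 to compound 3 (within the scatter), so this read-out does not tell the two compounds apart at this position. In a physicochemical assay for metabolic stability, read by LC-MS, in phosphate buffer, with a stated time of 3 h, at pH 7.4, tested at 50 uM (a lower number here means that less of the compound is left, a higher number that more of the compound is left), compound 2 gives > 95% as a limit of the assay and not a number. In the physicochemical assay compound 3 gives > 95% as a limit of the assay as well.

The step from compound 2 to compound 3 cannot be read in either assay, and in the buffer the reason is that both compounds sit at the same limit: the limit of > 95% in the physicochemical assay, at which 2 of the 2 values shown sit. From the compounds shown here alone, whether an amine or a carboxylic acid on the ester end, or a longer chain in place of ethoxy, would change how much compound is left in the plasma assay stays open.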